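Compound 4: 3-hydroxycyclohexyl on the amino group of compound 1

A few compounds are considered here, and "the series" means these few. Any claim that something is new, unique, unknown or untested is made for them only; others in the source may bear on it.

Compound 1 `Nc1cccc(CNc2cc(C(F)(F)F)cc3[nH]ncc23)c1` gives no number in an assay for inhibition of Indoleamine 2,3-dioxygenase 1 (Homo sapiens), with stated times of 10 min and 60 min; a lower number here means a stronger inhibitor, a higher number a weaker inhibitor: its result is a limit, > 100000 nM. The shared core is kept across the whole set. Compound 2 `FC(F)(F)c1cc(NC[C@H]2CCCCN2)c2cn[nH]c2c1` gives 24000 nM in this assay. Compound 3 `FC(F)(F)c1cc(NC[C@H]2CCCN2)c2cn[nH]c2c1` gives 9580 nM. The measured steps all exchange the entire 3-aminophenyl group: an at least 4.1-fold lower number from compound 1 to compound 2 (0.61 log units; beyond the scatter) and an at least 10-fold lower number from compound 1 to compound 3 (1.01 log units; beyond the scatter), both of which rest on the limit of > 100000 nM in this assay, at which 1 of the 3 values shown sits, for compound 1, and a 2.5-fold lower number from compound 2 to compound 3 (0.40 log units; beyond the scatter) between the two cyclic amines.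

Compound 4 `OC1CCCC(Nc2cccc(CNc3cc(C(F)(F)F)cc4[nH]ncc34)c2)C1` keeps the 3-aminophenyl and changes only its nitrogen: 3-hydroxycyclohexyl in place of hydrogen on a nitrogen on an aromatic ring. Among the compounds with values here, no measured step touches this position, so none of them tells how the added group shifts the number. Within the data shown here, the only anchor is compound 1, which sits at the limit of the assay, so a second result at the limit is about as likely as a number. The step of an at least 1.6-fold lower number from compound 1 to compound 4 (0.22 log units; that floor lies within the scatter) is therefore an estimate without measured backing in either direction. Compound 4 is expected near 60000 nM, within a range of 10000 nM to 300000 nM, with a real chance that only a limit is reported.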

Compound 4, half-maximal inhibitory concentration: > 100000 nM
Compound 4: only a limit was reported; the forecaster's own chance of this, stated with the estimate: 50%; middle value at least 1.6-fold (0.22 log units) from the limit.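

Compound 1 and compound 4 are both reported only as limits, so no step can be read between them: the limit of > 100000 nM in this assay, at which 2 of the 4 values shown sit.

The compounds shown leave open how far, or whether, 3-hydroxycyclohexyl in place of hydrogen on a nitrogen on an aromatic ring shifts the number in this assay.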